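The source may hold more compounds than are shown below. What is called first, only, known or untested is meant among the compounds shown, and "the series" means these compounds.

Working notes on the series: in a functional assay on Ehrlich cells (Mus musculus) for cytotoxicity, read by trypan blue exclusion, with a stated time of 2 h (on this read-out higher numbers stand for weaker inhibition and lower numbers for stronger inhibition), compound 1 `N#CC1=C(NC(=O)c2ccccc2)N(c2ccc(S(N)(=O)=O)cc2)C2=C(C(=O)CCC2)C1c1ccc(Cl)cc1Cl` gives 10 ug/mL and compound 2 `N#CC1=C(NC(=O)c2ccc([N+](=O)[O-])cc2)N(c2ccc(S(N)(=O)=O)cc2)C2=C(C(=O)CCC2)C1c1ccc(Cl)cc1Cl` gives 50 ug/mL, the higher of the two numbers. Compound 3 `CC(=O)CC(=O)NC1=C(C#N)C(c2ccc(Cl)cc2Cl)C2=C(CCCC2=O)N1c1ccc(S(N)(=O)=O)cc1` departs from compound 2 by 2-oxopropyl in place of 4-nitrophenyl on a carbonyl carbon, with 2-oxopropyl in place of 4-nitrophenyl on a carbonyl carbon. Going by a 5.0-fold higher number from compound 1 to compound 2 (0.70 log units; beyond the scatter), a modest step for nitro in place of hydrogen on an aromatic carbon, a step of similar or smaller size towards a lower number is expected in this assay, as nitro also leaves here. For the measured compounds named here, no measured step covers the loss of the aromatic ring, so the range stays wide. The expected change is a 2.5-fold lower number from compound 2 to compound 3 (0.40 log units; beyond the scatter). Compound 3 is estimated at 20 ug/mL, within 6 ug/mL to 60 ug/mL.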

Compound 3, half-maximal inhibitory concentration: 64 ug/mL
The estimate for compound 3 lay 3.2-fold (0.51 log units) below the measured number; measured number above the stated range.
By their numbers in this assay, from the lowest: compound 1; then compounds 2 and 3 (each within the scatter of the next).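

In this assay, 2-oxopropyl in place of 4-nitrophenyl on the carbonyl carbon gives a 1.3-fold higher number from compound 2 to compound 3 (0.11 log units; within the scatter) and so leaves the number unchanged despite the loss of the aromatic ring and its nitro group. 2-Oxopropyl in place of phenyl gives a 6.4-fold higher number from compound 1 to compound 3 (0.81 log units; beyond the scatter) at this position, so compound 1 stands apart from both compound 2 and compound 3. No available data explain these numbers.

On these data alone, whether the plain phenyl itself sets compound 1 apart remains open. So does the reading of an amine, a carboxylic acid or a longer chain on this carbonyl carbon.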